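The compounds below may be only part of what the source reports. "The series", "measured", "known", "first", "only" and "open" are said of these compounds alone.

Compound 1, `COc1ccc2c(c1)OC(c1cc(OC)c(OC)c(OC)c1)C(CO)=C2`, in a functional assay for inhibition of nuclear factor NF-kappa-B complex (Homo sapiens) (a higher number here means a weaker inhibitor, a lower number a stronger inhibitor), reaches only the assay limit > 50000 nM.
Compound 2, `COc1ccc2c(c1)OC(c1cc(OC)c(OC)c(OC)c1)C(C(=O)Nc1ccccc1)=C2`, in this assay gives 17500 nM.
Compound 3, `COC(=O)C1=Cc2ccc(OC)cc2OC1c1cc(OC)c(OC)c(OC)c1`, in this assay gives 13800 nM.

Compound 3 and compound 2 sit within the scatter of each other, the gap being a 1.3-fold lower number from compound 2 to compound 3 (0.10 log units; within the scatter). The unmeasured compound 4, `CCCC(=O)C1=Cc2ccc(OC)cc2OC1c1cc(OC)c(OC)c(OC)c1`, differs from compound 3 by propyl in place of methoxy on a carbonyl carbon. Of the measured steps, an at least 2.8-fold lower number from compound 1 to compound 2 (0.45 log units; beyond the scatter) and an at least 3.6-fold lower number from compound 1 to compound 3 (0.55 log units; beyond the scatter) altered the group on the double-bonded ring carbon; only a 1.3-fold lower number from compound 2 to compound 3 (0.10 log units; within the scatter) exchanged the substituent on the carbonyl carbon, and it stayed within the scatter. That step bears most directly on compound 4, so the expected step of a 1.0-fold higher number from compound 3 to compound 4 (0.01 log units; within the scatter) is none beyond the scatter. Compound 4 is therefore estimated at 14000 nM, between 5000 nM and 40000 nM.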

Compound 4, half-maximal inhibitory concentration: 11700 nM
For compound 4 the middle estimate is 1.2-fold (0.08 log units) above the measured one, within the range that was stated.
By their numbers in this assay, from the lowest: compounds 4, 3 and 2 (each within the scatter of the next). At a limit, above all of these: compound 1.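

In this assay, the carbonyl carbon has now carried methoxy, anilino and propyl with no step beyond the scatter: a 1.2-fold lower number from compound 3 to compound 4 (0.07 log units; within the scatter) and a 1.5-fold lower number from compound 2 to compound 4 (0.17 log units; within the scatter). Propyl, which enters with no hydrogen-bond acceptor, shows that among these compounds the group on the carbonyl carbon need not be joined through oxygen or nitrogen. The step of an at least 4.2-fold lower number from compound 1 to compound 4 (0.63 log units; beyond the scatter) is only a bound, since compound 1 stands at an assay limit: the limit of > 50000 nM in this assay, at which 1 of the 4 values shown sits.

Going by these compounds, whether a carboxylic acid, an amine or a longer chain on the carbonyl carbon would stay within this range remains open.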